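The source may report more compounds than this note shows. Statements on the series, on what has been measured and on what is new or still open speak of the compounds shown alone.

Series snapshot in an ADME assay on microsomes from liver (Homo sapiens) for metabolic stability, tested at 2.5 uM; on this read-out higher numbers stand for fast clearance and lower numbers for slow clearance:

compound 1 `O=S(=O)(c1ccc(F)cc1)c1cnc2cc(F)ccc2c1-c1ccc(F)cc1` gives 1.34 mL/min
compound 2 `O=S(=O)(c1ccc(F)cc1)c1cnc2cc(F)ccc2c1-c1ccc(Cl)cc1` gives 1.23 mL/min
compound 3 `O=S(=O)(c1ccc(F)cc1)c1cnc2cc(Cl)ccc2c1-c1ccc(Cl)cc1` gives 0.21 mL/min

Compound 2 sits with the second highest number of the three in this assay; compound 1 lies within the scatter of it a 1.1-fold lower number from compound 1 to compound 2 (0.04 log units; within the scatter), while compound 3 is clearly lower a 5.9-fold lower number from compound 2 to compound 3 (0.77 log units; beyond the scatter). Both measured steps concern chloro in place of fluoro on an aromatic carbon: the first, from compound 1 to compound 2, is within the scatter, and the second, from compound 2 to compound 3, is a modest step beyond it.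

Compound 4 `O=S(=O)(c1cccc(F)c1)c1cnc2cc(F)ccc2c1-c1ccc(Cl)cc1` is not yet measured. It differs from compound 2 only as follows: 3-fluorophenyl in place of 4-fluorophenyl on a sulfonyl sulfur. Among the measured compounds shown here, no measured step moves a substituent around a ring on the sulfonyl sulfur, so neither of the two steps bears directly on this change, and the data give no direction for it. For the measured compounds named here, with the same atoms joined differently and no precedent, the working expectation is a step within the scatter, a 1.0-fold lower number from compound 2 to compound 4 (0.01 log units; within the scatter), so that compound 4 is expected to land near compound 2 at 1.2 mL/min, with a range from 0.5 mL/min to 2.6 mL/min in this assay.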

Compound 4, intrinsic clearance in a liver preparation (reported as CLH), per the amount of preparation that the assay uses: 0.98 mL/min
Beside the measured number, compound 4's estimate is 1.2-fold (0.09 log units) above it, within the range that was stated.
By their numbers in this assay, from the lowest: compound 3; then compounds 4, 2 and 1 (each within the scatter of the next).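

Among the compounds shown here, this is the first read on the group on the sulfonyl sulfur: in this assay, 3-fluorophenyl in place of 4-fluorophenyl on a sulfonyl sulfur gives a 1.3-fold lower number from compound 2 to compound 4 (0.10 log units; within the scatter). For the compounds shown here, for this one pair, the read-out does not separate the two fluorophenyl groups, while the only step so far beyond the scatter, a 5.9-fold lower number from compound 2 to compound 3 (0.77 log units; beyond the scatter), is chloro in place of fluoro at another place. Nothing measured here speaks to why the two fluorophenyl groups read alike.

Open, on these data alone, is whether the sulfonyl sulfur accepts anything other than a fluorophenyl in this assay, for example a group carrying an amine or a carboxylic acid. Also open, as far as these compounds go, is whether 3-fluorophenyl gives an equally small step on the core of compound 3, which stands at 0.21 mL/min.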